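Swapping a Bromine for an Ester on the Benzyl Ring

The compounds below may be only part of what the source reports. "The series", "measured", "known", "first", "only" and "open" are said of these compounds alone.

Measured compounds and their values:
Compound 1, `O=C(O)Cn1c(SCc2cccc(Cl)c2)nc2ccccc21`: 186 nM
Compound 2, `COc1cccc(CSc2nc3ccccc3n2CC(=O)O)c1`: 72 nM
Compound 3, `O=C(O)Cn1c(SCc2cccc(Br)c2)nc2ccccc21`: 370 nM

All three share one core and differ only in the group on the benzyl ring, measured in an assay on HEK293 cells for displacement of a labelled ligand from prostaglandin D2 receptor 2 (Homo sapiens); a lower number here means a stronger inhibitor, a higher number a weaker inhibitor. Compound 3 has the highest number of the three. Its nearest neighbour is compound 1, with a 2.0-fold higher number from compound 1 to compound 3 (0.30 log units; within the scatter); its furthest is compound 2, with a 5.1-fold higher number from compound 2 to compound 3 (0.71 log units; beyond the scatter). The step from compound 1 to compound 2, a 2.6-fold lower number from compound 1 to compound 2 (0.41 log units; beyond the scatter), shows the same direction.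

Compound 4, `COC(=O)c1cccc(CSc2nc3ccccc3n2CC(=O)O)c1`, is the next step: methoxycarbonyl in place of bromo on an aromatic carbon. Within the data shown here, the only comparison that bears on this is the pair of compound 2 and compound 3, where a group carrying oxygen, methoxy, gave the lower number than bromo. Methoxycarbonyl also carries oxygen, though it is larger and different in shape, so the carry-over is uncertain. A modest drop in this assay is therefore expected, estimated as a 1.9-fold lower number from compound 3 to compound 4 (0.27 log units; within the scatter). Compound 4 is expected to give about 200 nM in this assay, within a range from 60 nM to 700 nM.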

Compound 4, half-maximal inhibitory concentration: 450 nM
The estimate for compound 4 lay 2.3-fold (0.35 log units) below the measured number; measured number inside the range.
By their numbers in this assay, from the lowest: compound 2; then compounds 1, 3 and 4 (each within the scatter of the next, the first and the last beyond it).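

In this assay, methoxycarbonyl and bromo cannot be told apart at this aromatic carbon, with a 1.2-fold higher number from compound 3 to compound 4 (0.09 log units; within the scatter) inside the usual scatter. Carrying oxygen is therefore not enough to match methoxy: a 6.3-fold higher number from compound 2 to compound 4 (0.80 log units; beyond the scatter) is a step beyond the scatter, and methoxycarbonyl also falls short of chloro, with a 2.4-fold higher number from compound 1 to compound 4 (0.38 log units; beyond the scatter) again beyond it. Nothing available here explains why these two oxygen-bearing groups give such different numbers.

Going by these compounds, whether the lower number of compound 2 belongs to methoxy alone stays open, and an ethoxy group, a hydroxyl or an amine on the same carbon would help to test that. The compounds shown also leave open how any of these groups would read on another carbon of the same ring.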